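Trifluoromethyl in place of methoxy: expected effect on cytotoxicity

This account rests on a few compounds, and the source may have more. Where it says the series, first, only, none or still open, it means among the compounds named here.

Compound 1 `O=C(OC[C@H]1CN(c2ccc(-n3cc(-c4ccccn4)cn3)c(F)c2)C(=O)O1)c1ccccc1`: in an ADME assay on L02 cells (Homo sapiens) for cytotoxicity, read by MTT assay, with a stated time of 48 h (on this read-out lower numbers stand for stronger inhibition and higher numbers for weaker inhibition), compound 1 gives > 400 ug/mL, which is a limit of the assay rather than a number.
Compound 2 `O=C1O[C@@H](Cn2ccnc2)CN1c1ccc(-n2cc(-c3ccccn3)cn2)c(F)c1`: compound 2 gives 350 ug/mL.
Compound 3 `COC(=O)NC[C@H]1CN(c2ccc(-n3cc(-c4ccccn4)cn3)c(F)c2)C(=O)O1`: compound 3 gives 71 ug/mL.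

Among the two numbers shown, compound 3 has the lowest. The step of a 4.9-fold lower number from compound 2 to compound 3 (0.69 log units; beyond the scatter) is beyond the scatter, and the step of an at least 5.6-fold lower number from compound 1 to compound 3 (0.75 log units; beyond the scatter) starts from a limit.

Compound 4 `O=C1O[C@@H](CNC(=O)C(F)(F)F)CN1c1ccc(-n2cc(-c3ccccn3)cn2)c(F)c1` differs from compound 3 by trifluoromethyl in place of methoxy on a carbonyl carbon. Every measured step here changes the group on the saturated chain carbon, not the group on the carbonyl carbon, so none bears directly on this change. No step beyond the scatter is therefore expected: a 1.1-fold higher number from compound 3 to compound 4 (0.05 log units; within the scatter). Compound 4 is estimated to give 80 ug/mL, with a range from 30 ug/mL to 250 ug/mL.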

Compound 4, half-maximal inhibitory concentration: > 400 ug/mL
Compound 4 gave a limit, no number; the forecaster's own chance of this, stated with the estimate: 15%; middle value at least 5.0-fold (0.69 log units) from the limit.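

In this assay, among these compounds, trifluoromethyl in place of methoxy on the carbonyl carbon gives an at least 5.6-fold higher number from compound 3 to compound 4 (0.75 log units; beyond the scatter), so the group on this carbonyl carbon, which the earlier compounds never varied, can shift cytotoxicity towards weaker inhibition. The comparison with the 1H-imidazol-1-yl compound gives an at least 1.1-fold higher number from compound 2 to compound 4 (0.05 log units; that floor lies within the scatter), which does not separate the two. The step from compound 1 to compound 4 cannot be read because both values are limits: the limit of > 400 ug/mL in this assay, at which 2 of the 4 values shown sit.

On these data alone, the true size of the trifluoromethyl effect remains open. So does whether methyl or an amine on this carbonyl carbon would behave like methoxy or like trifluoromethyl.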